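A few compounds are considered here, and "the series" means these few. Any claim that something is new, unique, unknown or untested is made for them only; others in the source may bear on it.

In a functional assay on HeLa cells (Homo sapiens) for inhibition, read by MTT assay, with a stated time of 48 h (on this read-out higher numbers stand for weaker inhibition and lower numbers for stronger inhibition), compound 1 (`O=C(CC(c1ccccc1)C(C(=O)Nc1ccccn1)C(=O)Nc1ccccn1)c1ccccc1`) gives 28100 nM and compound 3 (`O=C(CC(c1ccc(F)cc1)C(C(=O)Nc1ccccn1)C(=O)Nc1ccccn1)c1ccc(F)cc1`) gives 25500 nM. Going by the values given here, these two numbers lie within the usual scatter of each other, so compound 1 stands level with the only other compound that has a number. Compound 2 (`O=C(CC(c1ccccc1)C(C(=O)Nc1ccccn1)C(=O)Nc1ccccn1)c1ccc(F)cc1`) has no number and is reported as "not active" (no number reported).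

Compound 4 (`O=C(CC(c1cccs1)C(C(=O)Nc1ccccn1)C(=O)Nc1ccccn1)c1ccccc1`) has yet to be measured in this assay. It differs from compound 1 by having thiophen-2-yl in place of phenyl on a saturated chain carbon bound to two saturated chain carbons. Among the compounds with values here, no measured pair in this small set shows what such a replacement does, so the expectation rests on the values alone. Compound 1 at 28100 nM and compound 3 at 25500 nM suggest a number of the same order, though compound 2, reported as "not active" (no number reported), shows that a number is not assured in this series. No change beyond the scatter is expected, and the estimated step, a 1.1-fold lower number from compound 1 to compound 4 (0.03 log units; within the scatter), stays within it. Compound 4 is estimated at 26000 nM, with an expected range from 11000 nM to 60000 nM.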

Compound 4, half-maximal inhibitory concentration: "not active" (no number reported)
Compound 4: no number reported; the estimate stays without a comparison.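

Going by these compounds alone, compound 4 is reported as "not active" in this assay and carries no number, so no step from compound 1 can be read. The compounds shown leave open how far thiophen-2-yl in place of phenyl moves the read-out on the core of compound 1. Nothing measured here bears on this result.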